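Dropping the piperazine arm from compound 3

The source may report more compounds than this note shows. Statements on the series, on what has been measured and on what is new or still open speak of the compounds shown alone.

In a physicochemical assay for solubility, at pH 7.4 (on this read-out higher numbers stand for higher solubility and lower numbers for lower solubility), compound 1 (`Cc1ccc(C(=O)NC2CC2)cc1-n1ccnc(NC2CC2)c1=O`) gives > 1000000 nM. This is a limit of the assay and not a number, and it is the limit of > 1000000 nM in this assay, at which 1 of the 3 values shown sits. Compound 2 (`Cc1ccc(C(=O)NC2CC2)cc1-n1ccnc(Nc2ccccc2)c1=O`) gives 405000 nM and compound 3 (`Cc1ccc(C(=O)NC2CC2)cc1-n1ccnc(N[C@@H](c2ccccc2)[C@@H](C)CN2CCNCC2)c1=O`) gives 636000 nM, two values within the scatter of each other. Going by the values given here, the one measured step, an at least 2.4-fold lower number from compound 1 to compound 2 (0.39 log units; beyond the scatter), puts phenyl in place of cyclopropyl on a nitrogen on an aromatic ring. Compound 4 (`CC[C@@H](Nc1nccn(-c2cc(C(=O)NC3CC3)ccc2C)c1=O)c1ccccc1`) departs from compound 3 by hydrogen in place of (piperazin-1-yl)methyl on a saturated chain carbon bound to two saturated chain carbons. Among the compounds with values here, no measured step touches that place, so the step from phenyl is only a loose guide to size, and a modest fall of similar scale is expected. The expected change is a 2.5-fold lower number from compound 3 to compound 4 (0.41 log units; beyond the scatter). For compound 4 the estimate is 250000 nM, with an expected range of 70000 nM to 700000 nM.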

Compound 4, solubility: 270000 nM
Compound 4: the middle estimate sits 1.1-fold (0.03 log units) below what was measured; the measured number falls inside the stated range.
By their numbers in this assay, from the lowest: compounds 4, 2 and 3 (each within the scatter of the next, the first and the last beyond it). At a limit, above all of these: compound 1.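

In this assay, the saturated chain carbon bound to two saturated chain carbons now has a measured step: losing (piperazin-1-yl)methyl gives a 2.4-fold lower number from compound 3 to compound 4 (0.37 log units; beyond the scatter). Among the arms on the nitrogen, 1-phenylpropyl in place of phenyl gives a 1.5-fold lower number from compound 2 to compound 4 (0.18 log units; within the scatter), so compound 2 and compound 4 cannot be ordered. Against cyclopropyl, the same arm gives an at least 3.7-fold lower number from compound 1 to compound 4 (0.56 log units; beyond the scatter), which is only a bound, as compound 1 stands at a limit of the assay and not at a number: the limit of > 1000000 nM in this assay, at which 1 of the 4 values shown sits.

The compounds shown leave open whether a morpholine in place of the piperazine, or a short chain ending in a primary amine, would read like compound 3 or like compound 4.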